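Benzoyl in place of benzyl on the nitrogen

This account rests on a few compounds, and the source may have more. Where it says the series, first, only, none or still open, it means among the compounds named here.

In a functional assay on MKN-45 cells (Homo sapiens) for cytotoxicity (on this read-out lower numbers stand for stronger inhibition and higher numbers for weaker inhibition), compound 1 (`COc1ccc(S(=O)(=O)N2CCc3cccc(NC(=O)c4cccs4)c32)cc1`) gives 31 nM as its value. Compound 2 (`COc1ccc(S(=O)(=O)N2CCc3cccc(NCc4ccccc4)c32)cc1`) gives > 10000 nM as its reading, and this is a limit of the assay, not a number. Compound 3 (`COc1ccc(S(=O)(=O)N2CCc3cccc(NC(=O)c4ccccc4)c32)cc1`) has yet to be measured. The change from compound 2 is benzoyl in place of benzyl on a nitrogen on an aromatic ring, so that benzylamino becomes benzamido. Compound 3 thus carries a carbonyl on that nitrogen, as compound 1 does, although the ring attached to the carbonyl is not the same.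

Among the compounds with values here, only one measured step bears on this, and it is large: an at least 320-fold higher number from compound 1 to compound 2 (2.50 log units; beyond the scatter) when benzyl replaces (thiophen-2-yl)carbonyl at this place. A large step toward lower numbers is therefore expected, ending somewhat short of compound 1 or close to it, with the different ring as the main uncertainty. The expected step is an at least 120-fold lower number from compound 2 to compound 3 (2.09 log units; beyond the scatter) in this assay. For compound 3 the estimated value is 80 nM within an expected range from 20 nM to 400 nM in the same assay.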

Compound 3, half-maximal inhibitory concentration: 250 nM
Beside the measured number, compound 3's estimate is 3.1-fold (0.49 log units) below it; low and high end bracket the measured number.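

In this assay, benzyl and benzoyl carry the same six-membered aromatic ring of carbon only, so this change isolates the carbonyl on the nitrogen, and the result is large: an at least 40-fold lower number from compound 2 to compound 3 (1.60 log units; beyond the scatter). The earlier step replaced the ring and added the carbonyl at once, whereas the ring can now be read by itself, and it also counts, though less clearly than the carbonyl: an 8.1-fold higher number from compound 1 to compound 3 (0.91 log units; beyond the scatter). The first of these steps gives only a minimum size, because the reading for compound 2 is a limit of the assay and not a number: the limit of > 10000 nM in this assay, at which 1 of the 3 values shown sits.

The compounds shown leave open how a furan or pyridine ring on the carbonyl carbon would compare with phenyl and thiophen-2-yl, and so whether thiophen-2-yl is special or one of several rings that serve well here. They also leave open whether a ring is needed on the carbonyl at all, as an acetyl group would test, and whether a sulfonyl link on this nitrogen could stand in for the carbonyl.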